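One More Methoxy on the Aromatic Ring of Compound 1

A few compounds are considered here, and "the series" means these few. Any claim that something is new, unique, unknown or untested is made for them only; others in the source may bear on it.

- Compound 1 `COc1ccc(/C=C/C2(C)C=CC(=O)O2)c(OC)c1`: 80100 nM
- Compound 2 `COc1ccc(/C=C/C2(C)C=CC(=O)O2)c(OC)c1OC`: 71500 nM
- Compound 3 `COc1cc(OC)c(OC)cc1/C=C/C1(C)C=CC(=O)O1`: 127000 nM

These values come from a functional assay on UACC-62 cells (Homo sapiens) for inhibition, read by sulforhodamine B assay, with a stated time of 48 h; a lower number here means a stronger inhibitor of growth, a higher number a weaker inhibitor of growth. Compound 1 does not stand apart from the other two, as both its steps stay within the scatter. Compound 4 `COc1cc(OC)c(/C=C/C2(C)C=CC(=O)O2)c(OC)c1` differs from compound 1 by methoxy in place of hydrogen on an aromatic carbon. Two measured steps make the same kind of swap at other ring places: a 1.1-fold lower number from compound 1 to compound 2 (0.05 log units; within the scatter) and a 1.6-fold higher number from compound 1 to compound 3 (0.20 log units; within the scatter). Neither measured step puts a methoxy ortho to the group of 9 heavy atoms, so they offer only indirect guidance. Even so, no step beyond the scatter is expected in this assay. The estimated step is a 1.1-fold higher number from compound 1 to compound 4 (0.05 log units; within the scatter). For compound 4 the expected value is 90000 nM, with an estimated range of 50000 nM to 160000 nM.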

Compound 4, concentration for total growth inhibition: 208000 nM
Estimate against measurement, compound 4: 2.3-fold (0.36 log units) below, outside the stated range (above it).
By their numbers in this assay, from the lowest: compounds 2, 1, 3 and 4 (each within the scatter of the next, the first and the last beyond it).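

Placed on an aromatic carbon ortho to a group of 9 heavy atoms, the methoxy gives a 2.6-fold higher number from compound 1 to compound 4 (0.41 log units; beyond the scatter) and makes compound 4 a weaker inhibitor of growth than compound 1. Among the three swaps of hydrogen for methoxy shown, only this one goes beyond the scatter, so the place on the ring matters for this change. No measurement at hand explains the loss.

From the compounds shown here alone, whether a smaller group in this same place, such as a fluorine atom or a hydroxyl, would also weaken growth inhibition stays open.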